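A few compounds are considered here, and "the series" means these few. Any claim that something is new, unique, unknown or untested is made for them only; others in the source may bear on it.

Measured compounds:
- Compound 1, `CCCCC(C(=O)OC)N1C(=O)/C(=C/c2ccc(C(=O)N[C@@H](CCCNC(=N)N)C(=O)N[C@@H](CCCCN)C(=O)N[C@@H](CCCC)C(N)=O)cc2)SC1=S`: 0.87 10^-6 cm/s
- Compound 2, `CCCC[C@H](NC(=O)[C@H](CCCCN)NC(=O)[C@H](CCCNC(=N)N)NC(=O)c1ccc(/C=C2\SC(=O)N(Cc3ccc(F)cc3)C2=O)cc1)C(N)=O`: 0.43 10^-6 cm/s
- Compound 3, `CCCC[C@H](NC(=O)[C@H](CCCCN)NC(=O)[C@H](CCCNC(=N)N)NC(=O)c1ccc(/C=C2\SC(=S)N(c3ccc(Cl)cc3)C2=O)cc1)C(N)=O`: 1.02 10^-6 cm/s

These three compounds share the same peptide-bearing core and were tested in an ADME assay for permeability, using PAMPA; on this read-out lower numbers stand for lower permeability and higher numbers for higher permeability. Among the three numbers, compound 3 stands highest, with compound 1 nearest to it and compound 2 furthest; the gap to compound 1 lies within the scatter, while the gap to compound 2 lies beyond it. Compound 2 differs from the others in more than one place, so its value offers no single clean comparison.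

The unmeasured compound 4, `C=CCN1C(=O)/C(=C/c2ccc(C(=O)N[C@@H](CCCNC(=N)N)C(=O)N[C@@H](CCCCN)C(=O)N[C@@H](CCCC)C(N)=O)cc2)SC1=S`, differs from compound 3 in one place: allyl in place of 4-chlorophenyl on an amide-type nitrogen in a ring. For the measured compounds named here, one measured step bears on this position. Replacing one group with another on the same amide-type nitrogen gave a 1.2-fold higher number from compound 1 to compound 3 (0.07 log units; within the scatter), a change no larger than the noise of repeated measurement. On that basis, the step of a 1.3-fold lower number from compound 3 to compound 4 (0.11 log units; within the scatter) is expected to stay within the scatter, with no clear direction. Compound 4 is therefore estimated to give 0.8 10^-6 cm/s in this assay, with a plausible range from 0.4 10^-6 cm/s to 1.6 10^-6 cm/s.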

Compound 4, apparent permeability: 0.42 10^-6 cm/s
Beside the measured number, compound 4's estimate is 1.9-fold (0.28 log units) above it; the range from low to high includes it.
By their numbers in this assay, from the lowest: compounds 4 and 2 (each within the scatter of the next); then compounds 1 and 3 (each within the scatter of the next).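

In this assay, the group on the amide-type nitrogen in the ring now proves able to shift the number, since the earlier step at this position stayed within the scatter. Allyl in place of 4-chlorophenyl gives a 2.4-fold lower number from compound 3 to compound 4 (0.39 log units; beyond the scatter), and allyl in place of 1-(methoxycarbonyl)pentyl gives a 2.1-fold lower number from compound 1 to compound 4 (0.32 log units; beyond the scatter), so two quite different groups both stand modestly above allyl, which has only 3 heavy atoms and no ring. Nothing measured here explains this drop.

The compounds shown leave open how a saturated propyl chain or an unsubstituted phenyl ring would read at this nitrogen, and these two groups could help separate the roles of the double bond in allyl, the chlorine and the ring. Also open, as far as these compounds go, is where an amine or a carboxylic acid at the end of a longer chain would fall at the same place, and whether the same steps would hold with the rest of the molecule changed.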